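Three Aryl Groups Measured, a Fourth Awaiting Its Number

The compounds below may be only part of what the source reports. "The series", "measured", "known", "first", "only" and "open" are said of these compounds alone.

Compound 1 `COc1cncc(-c2c(C)nn(-c3nc(-c4ccc(Cl)c(Cl)c4)c(SC(C)C)s3)c2C(=O)O)c1`: 21000 nM
Compound 2 `Cc1ccccc1-c1c(C)nn(-c2nc(-c3ccc(Cl)c(Cl)c3)c(SC(C)C)s2)c1C(=O)O`: 5500 nM
Compound 3 `Cc1nn(-c2nc(-c3ccc(Cl)c(Cl)c3)c(SC(C)C)s2)c(C(=O)O)c1-c1cnn(C)c1`: 6800 nM

In a functional assay on BJAB cells (Homo sapiens) for antiproliferative activity, with a stated time of 4 days (on this read-out lower numbers stand for an effect already at smaller amounts and higher numbers for an effect only at larger amounts of compound), compound 2 gives 5500 nM, the lowest of the three numbers; compound 3 lies within the scatter of it, while compound 1 stands furthest away. Compound 4 `Cc1nn(-c2nc(-c3ccc(Cl)c(Cl)c3)c(SC(C)C)s2)c(C(=O)O)c1-c1cccc(F)c1` has not been measured. It differs from compound 2 by 3-fluorophenyl in place of 2-methylphenyl on an aromatic carbon. All three measured steps vary the group at this same aromatic carbon: a 3.8-fold lower number from compound 1 to compound 2 (0.58 log units; beyond the scatter), a 3.1-fold lower number from compound 1 to compound 3 (0.49 log units; beyond the scatter), and a 1.2-fold higher number from compound 2 to compound 3 (0.09 log units; within the scatter). The last of these, an exchange between two groups of equal atom count, stayed within the scatter, and the present change likewise swaps one six-membered carbon ring for another of equal size. The step of a 1.1-fold higher number from compound 2 to compound 4 (0.04 log units; within the scatter) is therefore expected to remain within the scatter. Compound 4 is estimated at 6000 nM, with a range from 2500 nM to 15000 nM.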

Compound 4, half-maximal effective concentration: 900 nM
The estimate for compound 4 lay 6.7-fold (0.82 log units) above the measured number; the measured number lies below the stated range.
By their numbers in this assay, from the lowest: compound 4; then compounds 2 and 3 (each within the scatter of the next); then compound 1.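

In this assay, this aromatic carbon on the five-membered ring proves able to separate two carbon-only aromatic rings of equal heavy-atom count: 3-fluorophenyl in place of 2-methylphenyl gives a 6.1-fold lower number from compound 2 to compound 4 (0.79 log units; beyond the scatter). The 3-fluorophenyl group also stands apart from the other two groups, with a 7.6-fold lower number from compound 3 to compound 4 (0.88 log units; beyond the scatter) and a 23-fold lower number from compound 1 to compound 4 (1.37 log units; beyond the scatter), the largest step in the set. No measurement at hand says why this change acts as it does.

The compounds shown do not separate the arrival of the fluorine from the departure of the methyl. An unsubstituted phenyl or a chlorophenyl at this carbon would speak to that.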